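The compounds below may be only part of what the source reports. "The series", "measured", "known", "first", "only" and "open" are said of these compounds alone.

Measured in a functional assay on A549 cells (Homo sapiens) for inhibition, read by sulforhodamine B assay, with a stated time of 72 h; a higher number here means a weaker inhibitor, a lower number a stronger inhibitor:
- compound 1 `Nc1sc(-c2ccc(Cl)cc2)c(-c2ccc(Cl)cc2)c1C(=O)N1CCCCC1=O`: 1820 nM
- compound 2 `Nc1sc(-c2ccc(Cl)cc2)c(-c2ccc(Cl)cc2)c1C(=O)NC1CCCCC1`: 2410 nM
- compound 3 `CCOC(=O)Nc1sc(-c2ccc(Cl)cc2)c(-c2ccc(Cl)cc2)c1C(=O)NC1CC1`: 39800 nM

Compound 2 (2410 nM) lies within the scatter of compound 1, while compound 3 shows a much higher number (39800 nM). Compound 4 `Nc1sc(-c2ccc(Cl)cc2)c(-c2ccc(Cl)cc2)c1C(=O)NC1CCC(O)CC1` carries hydroxy in place of hydrogen on a saturated ring carbon, three ring bonds from the ring atom that bears a large group (hydroxy in place of hydrogen on a saturated ring carbon). For the measured compounds named here, no measured step adds a hydroxy. Going by the values given here, the only measured step, a 1.3-fold higher number from compound 1 to compound 2 (0.12 log units; within the scatter), exchanges the whole group on the carbonyl carbon and stays within the scatter. A shift beyond the scatter is therefore not expected, and the estimated step is a 1.2-fold higher number from compound 2 to compound 4 (0.10 log units; within the scatter). For compound 4 the expected value is 3000 nM, with an estimated range of 1000 nM to 10000 nM.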

Compound 4, half-maximal inhibitory concentration: 250 nM
The estimate for compound 4 lay 12-fold (1.08 log units) above the measured number; measured number below the stated range.
By their numbers in this assay, from the lowest: compound 4; then compounds 1 and 2 (each within the scatter of the next); then compound 3.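

In this assay, hydroxy in place of hydrogen on a saturated ring carbon, three ring bonds from the ring atom that bears a large group, gives a 9.6-fold lower number from compound 2 to compound 4 (0.98 log units; beyond the scatter), so this position responds to a single added oxygen. Exchanging the whole group on the carbonyl carbon, which had stayed within the scatter, now gives a 7.3-fold lower number from compound 1 to compound 4 (0.86 log units; beyond the scatter) when the entering group is (4-hydroxycyclohexyl)amino. No available evidence explains this gain. The compounds shown leave open whether a methoxy, an amine or a carboxylic acid on the same ring carbon would match hydroxy.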